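Swapping the sulfonyl aryl group in a quinoline binder

The source may report more compounds than this note shows. Statements on the series, on what has been measured and on what is new or still open speak of the compounds shown alone.

Of the compounds shown here, two have been measured in an assay on isolated protein for displacement of a labelled ligand from metabotropic glutamate receptor 5 (Homo sapiens), with a stated time of 60 min, tested at 1 uM; on this read-out lower numbers stand for less inhibition and higher numbers for more inhibition at the one concentration tested (going by the name of the read-out). Compound 2 `Cc1ccc(S(=O)(=O)c2cnc3ccc(Cl)cc3c2N2CCC(C)CC2)cc1` gives 95%, the highest of the two numbers seen so far. Compound 1 `COc1ccc2ncc(S(=O)(=O)c3cccc(C#N)c3)c(N3CCC(C)CC3)c2c1` gives 90% in this assay, a value within the scatter of compound 2, so the two cannot be told apart on these numbers alone.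

Compound 3 `CC1CCN(c2c(S(=O)(=O)c3cccc(C#N)c3)cnc3ccc(Cl)cc23)CC1` has not yet been measured. It differs from compound 2 in one place: 3-cyanophenyl in place of 4-methylphenyl on a sulfonyl sulfur. Since both measured compounds show strong displacement, no step beyond the scatter is anticipated in either direction. The step from compound 2 to compound 3 is expected to amount to a number 3 percentage points lower from compound 2 to compound 3 (within the scatter), a change no larger than the scatter. Compound 3 is therefore estimated to give 92% in this assay, with a likely range from 80% to 99%.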

Compound 3, a percentage reported as inhibition, at one concentration (the size of the read-out at that concentration, not a potency): 90%
Compound 3: middle estimate off by 2 percentage points, on the high side; low and high end bracket the measured number.
By their numbers in this assay, from the lowest: compounds 1, 3 and 2 (each within the scatter of the next).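

In this assay, 3-cyanophenyl in place of 4-methylphenyl on a sulfonyl sulfur gives a number 5 percentage points lower from compound 2 to compound 3 (within the scatter), so with the rest of the molecule held the same, either aryl group fits this position without a step that can be told from the scatter. With 3-cyanophenyl kept, chloro in place of methoxy on an aromatic carbon gives no change at the digits printed from compound 1 to compound 3 (within the scatter), so that second place also shows no step beyond the scatter. No other measurement shown bears on this result.

On these data alone, it remains open whether a quite different group on the sulfonyl sulfur, such as an amine, a carboxylic acid or a longer alkyl chain, would keep the read-out at this level. As far as these compounds go, a reading at one concentration is not a potency, so any difference in potency behind these numbers also remains open.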